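The compounds below may be only part of what the source reports. "The series", "measured", "known", "first", "only" and "open" are said of these compounds alone.

Measured compounds:
compound 1, `COc1cc(OC)c(OC)cc1/C=C/C(=O)c1cc(Cl)ccc1O` — > 150000 nM
compound 2, `COc1cc(OC)c(-c2cc(=O)c3cc(O)ccc3o2)cc1OC` — > 150000 nM

The series is read in a functional assay on MCF7 cells (Homo sapiens) for inhibition, read by MTT assay, with a stated time of 72 h; a lower number here means a stronger inhibitor, a higher number a weaker inhibitor. Compound 1, `COc1cc(OC)c(OC)cc1/C=C/C(=O)c1cc(Cl)ccc1O`, gives > 150000 nM; that is a limit of the assay, not a number. Compound 2, `COc1cc(OC)c(-c2cc(=O)c3cc(O)ccc3o2)cc1OC`, gives > 150000 nM; this too is a limit. Among the measured compounds shown here, compound 1 therefore stands at the limit of > 150000 nM in this assay, at which 2 of the 2 values shown sit, and no measured step between compounds is available to set a scale for the change considered here.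

The unmeasured compound 3, `COc1ccc(C(=O)/C=C/c2cc(OC)c(OC)cc2OC)cc1`, differs from compound 1 in one place: 4-methoxyphenyl in place of 5-chloro-2-hydroxyphenyl on a carbonyl carbon. With compound 1 resting at a limit, no direction can be derived from the numbers; the expectation for this assay is a step no larger than the scatter, with compound 3 most likely also reported as a limit. Compound 3 is expected to give 120000 nM, within 30000 nM to 300000 nM. The change from compound 1 to compound 3 that this estimate means is an at least 1.2-fold lower number from compound 1 to compound 3 (0.09 log units; that floor lies within the scatter), and it is an expectation only.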

Compound 3, half-maximal inhibitory concentration: 33900 nM
Beside the measured number, compound 3's estimate is 3.5-fold (0.55 log units) above it; low and high end bracket the measured number.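

In this assay, among the compounds shown here, the exchange of 5-chloro-2-hydroxyphenyl for 4-methoxyphenyl on a carbonyl carbon provides the first measurable change and shows that this position can affect the read-out: an at least 4.4-fold lower number from compound 1 to compound 3 (0.64 log units; beyond the scatter). For the compounds shown here, the size of this step is only a floor, because compound 1 gives a limit of the assay and not a number: the limit of > 150000 nM in this assay, at which 2 of the 3 values shown sit. The single exchange removes the chlorine and the hydrogen-bond donor of the leaving group and brings in the methoxy group, so the step belongs to the exchange as a whole and not to any one of these parts.

The compounds shown leave open how much of the step goes with the loss of the chlorine, the loss of the hydroxyl or the gain of the methoxy group. They also leave open how this assay would read for other aromatic groups on the same carbonyl carbon, such as a phenyl ring carrying an amine or a carboxylic acid.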